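Chloro next to fluoro on the triazole aryl group

This account rests on a few compounds, and the source may have more. Where it says the series, first, only, none or still open, it means among the compounds named here.

Measured compounds: compound 1 `Cc1c(C(=O)Nc2ccc(Oc3ccnc4[nH]ccc34)c(F)c2)nnn1-c1ccc(F)cc1`, 120 nM; compound 2 `Cc1c(C(=O)Nc2ccc(Oc3ccnc4[nH]ccc34)c(F)c2)nnn1-c1ccc(F)c(Cl)c1`, 1060 nM; compound 3 `O=C(Nc1ccc(Oc2ccnc3[nH]ccc23)cc1)c1nnn(-c2ccc(F)cc2)c1C(F)(F)F`, 93 nM.

In a functional assay on HT-29 cells (Homo sapiens) for cytotoxicity, read by MTT assay, with a stated time of 72 h (a lower number here means a stronger inhibitor, a higher number a weaker inhibitor), compound 1 gives 120 nM and compound 2 gives 1060 nM; the step of an 8.8-fold higher number from compound 1 to compound 2 (0.95 log units; beyond the scatter) is the change (chloro in place of hydrogen on an aromatic carbon). Compound 3 gives 93 nM, and its difference from compound 1 is not broken down here. Compound 4 `O=C(Nc1ccc(Oc2ccnc3[nH]ccc23)cc1)c1nnn(-c2ccc(F)c(Cl)c2)c1C(F)(F)F` is not yet measured; it differs from compound 3 by chloro in place of hydrogen on an aromatic carbon, the same change as that from compound 1 to compound 2, at a place described in the same words. Because of an 8.8-fold higher number from compound 1 to compound 2 (0.95 log units; beyond the scatter), a step of similar size is expected in this assay from compound 3 to compound 4, namely an 8.1-fold higher number from compound 3 to compound 4 (0.91 log units; beyond the scatter). Compound 4 is therefore estimated at 750 nM, between 250 nM and 2500 nM.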

Compound 4, half-maximal inhibitory concentration: 1020 nM
Beside the measured number, compound 4's estimate is 1.4-fold (0.13 log units) below it; the range from low to high includes it.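

In this assay the change from 4-fluorophenyl to 3-chloro-4-fluorophenyl again weakens the compound, with an 11-fold higher number from compound 3 to compound 4 (1.04 log units; beyond the scatter). Set beside the earlier step, the two agree in size: the same change on two cores in this assay, an 8.8-fold higher number (0.95 log units; beyond the scatter) from compound 1 to compound 2 and an 11-fold higher number (1.04 log units; beyond the scatter) from compound 3 to compound 4, 1.2-fold (0.09 log units) apart, within the scatter of two such steps So in this series the cost of the chloro group carried over between these two cores, but two pairs cannot show that it would hold on any other core, and they do not explain the loss.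

The compounds shown leave open whether a bromo, methoxy or nitrile group at that aromatic carbon would cost as much. They also leave open whether chloro would have the same effect on a phenyl ring without the fluoro group.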